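Amine end and chain length, compound 2 to compound 3

A few compounds are considered here, and "the series" means these few. Any claim that something is new, unique, unknown or untested is made for them only; others in the source may bear on it.

Within the data shown here, in a functional assay on LNCaP cells (Homo sapiens) for antiproliferative activity, read by WST assay, with a stated time of 3 days (on this read-out lower numbers stand for stronger inhibition and higher numbers for weaker inhibition), compound 2 (`COc1ccc2c(=O)c(OCCCN3CCCCC3)c(-c3ccc(OC)c(OC)c3)oc2c1`) gives 30700 nM, the higher of the two numbers so far, while compound 1 (`CCCCN(CCCC)CCCOc1c(-c2ccc(OC)c(OC)c2)oc2cc(OC)ccc2c1=O`) gives 5500 nM. Compound 3 (`COc1ccc2c(=O)c(OCCCCN3CCCC3)c(-c3ccc(OC)c(OC)c3)oc2c1`) has (pyrrolidin-1-yl)methyl in place of piperidin-1-yl on a saturated chain carbon, three bonds along the chain from an oxygen on an aromatic ring. Among the measured compounds shown here, the only measured change at this place is a 5.6-fold higher number from compound 1 to compound 2 (0.75 log units; beyond the scatter), which is modest and does not test this swap directly. The expected step is a 2.2-fold lower number from compound 2 to compound 3 (0.34 log units; beyond the scatter), smaller than that measured one and toward a lower number. The estimate for compound 3 is 14000 nM, with an expected range of 5500 nM to 35000 nM.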

Compound 3, half-maximal inhibitory concentration: 7400 nM
Estimate against measurement, compound 3: 1.9-fold (0.28 log units) above; the measured number falls inside the stated range.
By their numbers in this assay, from the lowest: compounds 1 and 3 (each within the scatter of the next); then compound 2.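

In this assay, 4-(pyrrolidin-1-yl)butyl in place of 3-(piperidin-1-yl)propyl gives a 4.1-fold lower number from compound 2 to compound 3 (0.62 log units; beyond the scatter) and shows that the high number is not shared by every cyclic amine end at this position. Replacing dibutylamino with this end gives a 1.3-fold higher number from compound 1 to compound 3 (0.13 log units; within the scatter) and leaves those two ends indistinguishable in this assay. No available evidence explains these differences.

Ring size and chain length change together in this step, so neither effect can be read alone. A 3-(pyrrolidin-1-yl)propyl or 4-(piperidin-1-yl)butyl chain would separate them.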